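A Thiophene Swap on an Unchanged Core

A few compounds are considered here, and "the series" means these few. Any claim that something is new, unique, unknown or untested is made for them only; others in the source may bear on it.

Growth inhibition values from a functional assay on K562 cells (Homo sapiens) for antiproliferative activity, read by MTT assay, with a stated time of 48 h (a higher number here means a weaker inhibitor of growth, a lower number a stronger inhibitor of growth), follow
- compound 1 `CCOc1cc(NC(=O)CCCCCC(=O)Nc2cc(-c3ccccc3)ccc2N)cc2c1OCC([N+](=O)[O-])=C2` gives 3210 nM
- compound 2 `CCOc1cc(NC(=O)CCCCC(=O)Nc2cc(-c3ccccc3)ccc2N)cc2c1OCC([N+](=O)[O-])=C2` gives 5270 nM

In this assay, among the measured compounds shown here, only two compounds have been measured so far. The value of compound 2 lies within the usual scatter of the value of compound 1, so the two cannot be told apart, and both sit in the same range of micromolar-level numbers.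

Compound 3 `CCOc1cc(NC(=O)CCCCC(=O)Nc2cc(-c3ccc(C)s3)ccc2N)cc2c1OCC([N+](=O)[O-])=C2` keeps the rest of compound 2 but carries 5-methylthiophen-2-yl in place of phenyl on an aromatic carbon of a six-membered aromatic ring of carbon only. For the measured compounds named here, the measured compounds include no example of this swap. Only a small shift towards a lower number, within the scatter, is expected (a 1.5-fold lower number from compound 2 to compound 3 (0.18 log units; within the scatter)). Compound 3 is estimated at 3500 nM (1500 nM to 8000 nM).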

Compound 3, concentration for 50% growth inhibition: 2940 nM
The estimate for compound 3 lay 1.2-fold (0.08 log units) above the measured number; measured number inside the range.
By their numbers in this assay, from the lowest: compounds 3, 1 and 2 (each within the scatter of the next).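

In this assay, the aromatic carbon para to an amino group takes 5-methylthiophen-2-yl in place of phenyl, with a 1.8-fold lower number from compound 2 to compound 3 (0.25 log units; within the scatter). Compounds 1 and 2 both carry phenyl there and so said nothing about this position, whereas compound 3 shows that a five-membered aromatic ring with 1 hetero atom can stand in for a six-membered aromatic ring of carbon only without separating the two compounds in this read-out. Nothing at hand offers an explanation for this result.

As far as these compounds go, it remains open whether a group of another kind at this position, such as an amine, a carboxylic acid or thiophen-2-yl without its methyl, would stand apart from phenyl. From the compounds shown here alone, it is also open whether 5-methylthiophen-2-yl gives the same picture on the longer chain of compound 1.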